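Methyl to Hydrogen on an Aromatic Oxygen: Cytotoxicity Outlook

The source may hold more compounds than are shown below. What is called first, only, known or untested is meant among the compounds shown, and "the series" means these compounds.

Of the compounds shown here, three have been tested in a functional assay on HSG cells (Homo sapiens) for cytotoxicity; on this read-out lower numbers stand for higher toxicity in this test and higher numbers for lower toxicity in this test. Compound 1 `COc1cc(/C=C2\CCC/C(=C\c3ccc([N+](=O)[O-])cc3)C2=O)ccc1O` gives 11000 nM, compound 3 `COc1ccc(/C=C2\CCC/C(=C\c3ccc([N+](=O)[O-])cc3)C2=O)cc1OC` gives 13000 nM, and compound 2 `COc1ccc(/C=C2\Cc3ccccc3/C(=C\c3ccc([N+](=O)[O-])cc3)C2=O)cc1` gives 47000 nM. Compound 3 and compound 1 differ by hydrogen in place of methyl on an oxygen on an aromatic ring, and that change made a 1.2-fold lower number from compound 3 to compound 1 (0.07 log units; within the scatter). Compound 4 `O=C1/C(=C/c2ccc(O)cc2)Cc2ccccc2/C1=C\c1ccc([N+](=O)[O-])cc1` has not been measured; it differs from compound 2 by hydrogen in place of methyl on an oxygen on an aromatic ring, the same change at a place described in the same words. How the core of compound 2 differs from the core of compound 3 is not broken down here; the two values show compound 2 with the higher number. Because the earlier step of a 1.2-fold lower number from compound 3 to compound 1 (0.07 log units; within the scatter) stayed within the scatter, the expected step in this assay is also small, a 1.2-fold lower number from compound 2 to compound 4 (0.07 log units; within the scatter). Compound 4 is therefore estimated at 40000 nM, likely between 15000 nM and 110000 nM.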

Compound 4, half-maximal cytotoxic concentration: 11000 nM
For compound 4 the middle estimate is 3.6-fold (0.56 log units) above the measured one; measured number below the stated range.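

In this assay the swap of methoxy to hydroxy gave a 4.3-fold lower number from compound 2 to compound 4 (0.63 log units; beyond the scatter) on this second core, so the change did not carry across at one size. Set beside the earlier step, the two results differ: the same change on two cores in this assay, a 1.2-fold lower number (0.07 log units; within the scatter) from compound 3 to compound 1 and a 4.3-fold lower number (0.63 log units; beyond the scatter) from compound 2 to compound 4, 3.6-fold (0.56 log units) apart, beyond the scatter of two such steps
The size of this change was therefore not the same on these two cores, but two pairs give no general rule for the series, and they do not show which feature of a core is responsible.

The compounds shown leave open how an amine or a longer chain such as ethoxy would behave in place of the hydroxy on either core. They also leave open which of the two step sizes, if either, a further core would follow.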